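A Triazole-Nitrogen Swap Toward a Two-Ring Isoquinoline Group

A few compounds are considered here, and "the series" means these few. Any claim that something is new, unique, unknown or untested is made for them only; others in the source may bear on it.

Three compounds share one core and differ only in the group on an aromatic nitrogen of the five-membered ring with three nitrogens. Compound 1 `O[C@H](COCCOC[C@@H](O)Cc1cn(Cc2ccc3ccccc3c2)nn1)Cc1ccc(-c2ccccc2)cc1` gives 8600 nM in a functional assay on HCT-116 cells (Homo sapiens) for inhibition, read by MTT assay, with a stated time of 72 h; a lower number here means a stronger inhibitor of growth, a higher number a weaker inhibitor of growth. Compound 2 `O[C@H](COCCOC[C@@H](O)Cc1cn(-c2cccnc2)nn1)Cc1ccc(-c2ccccc2)cc1` gives 46800 nM in this assay, and compound 3 `O[C@H](COCCOC[C@@H](O)Cc1cn(Cc2ccc(C(F)(F)F)cc2)nn1)Cc1ccc(-c2ccccc2)cc1` gives 2500 nM, the lowest of the three numbers. The step of a 3.4-fold lower number from compound 1 to compound 3 (0.54 log units; beyond the scatter) and the step of a 19-fold lower number from compound 2 to compound 3 (1.27 log units; beyond the scatter) both set compound 3 apart from its neighbours beyond the scatter.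

Compound 4 `O[C@H](COCCOC[C@@H](O)Cc1cn(-c2cncc3ccccc23)nn1)Cc1ccc(-c2ccccc2)cc1` has not yet been measured. It carries isoquinolin-4-yl in place of 4-(trifluoromethyl)benzyl on an aromatic nitrogen. Among the measured compounds shown here, two measured steps bear on this change. The step of a 5.4-fold higher number from compound 1 to compound 2 (0.74 log units; beyond the scatter) shows that moving from a two-ring group joined through a saturated carbon to a nitrogen-containing ring bound directly to the aromatic nitrogen gave a weaker inhibitor, and the step of a 19-fold lower number from compound 2 to compound 3 (1.27 log units; beyond the scatter) shows a large gain when a benzyl-type group took its place. Compound 4 has a directly bound nitrogen-containing ring, as compound 2 does, yet a two-ring system, as compound 1 does. A rise in the number is therefore expected: a 6.0-fold higher number from compound 3 to compound 4 (0.78 log units; beyond the scatter). Compound 4 is estimated at 15000 nM, with a range from 5000 nM to 50000 nM.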

Compound 4, concentration for 50% growth inhibition: 17800 nM
Estimate against measurement, compound 4: 1.2-fold (0.07 log units) below, and the stated range covers the measured number.
By their numbers in this assay, from the lowest: compound 3; then compound 1; then compound 4; then compound 2.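

Adding a second ring to a nitrogen-containing group bound directly to the aromatic nitrogen helps only a little: in this assay, isoquinolin-4-yl in place of pyridin-3-yl gives a 2.6-fold lower number from compound 2 to compound 4 (0.42 log units; beyond the scatter). That two-ring group still trails both groups joined through a saturated carbon, with a 2.1-fold higher number from compound 1 to compound 4 (0.32 log units; beyond the scatter) and a 7.1-fold higher number from compound 3 to compound 4 (0.85 log units; beyond the scatter), so among these four compounds the two directly bound groups give the two highest numbers, and no compound goes against this. No evidence is available that explains these differences.

The compounds shown do not separate the effect of the saturated carbon link from that of the ring it carries, as each such step changes both. An isoquinolin-4-ylmethyl group would address this, and a benzyl group carrying an amine or a carboxylic acid instead of trifluoromethyl would show how far that substituent can vary.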